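The compounds below may be only part of what the source reports. "The series", "measured", "known", "first", "only" and "open" are said of these compounds alone.

Measured in a functional assay on NUGC cells (Homo sapiens) for cytotoxicity; on this read-out higher numbers stand for weaker inhibition and lower numbers for stronger inhibition:
- Compound 1 `O=C1C=CC[C@H]([C@@H](O)[C@H](Cl)c2ccccc2)O1`: 31 ug/mL
- Compound 2 `CO[C@H](c1ccccc1)[C@H](O)[C@H]1CC=CC(=O)O1`: 168 ug/mL

Compound 2 holds the higher of the two numbers, and so shows the weaker inhibition of the pair. Compound 3 `CC(=O)O[C@H](c1ccccc1)[C@H](O)[C@H]1CC=CC(=O)O1` departs from compound 2 by one change, acetyl in place of methyl on an oxygen on a saturated carbon, or methoxy to acetoxy. For the measured compounds named here, no measured step covers this change. The nearest evidence is a 5.4-fold higher number from compound 1 to compound 2 (0.73 log units; beyond the scatter), a modest step beyond the scatter, in which methoxy replaced chloro on a saturated chain carbon. Going by the values given here, it shows only that a swap of this kind can move the number. A smaller step towards stronger inhibition is therefore expected, with little certainty about its direction. The expected change is a 1.9-fold lower number from compound 2 to compound 3 (0.27 log units; within the scatter). For compound 3 the estimated value is 90 ug/mL, with an expected range of 30 ug/mL to 220 ug/mL.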

Compound 3, half-maximal inhibitory concentration: 5.02 ug/mL
Beside the measured number, compound 3's estimate is 18-fold (1.25 log units) above it; the whole stated range lies above it.
By their numbers in this assay, from the lowest: compound 3; then compound 1; then compound 2.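

In this assay, the substituent on the saturated carbon proves far more sensitive than the earlier pair could show: acetyl in place of methyl on the oxygen gives a 33-fold lower number from compound 2 to compound 3 (1.52 log units; beyond the scatter) and is a large step. Acetoxy in place of chloro gives a 6.2-fold lower number from compound 1 to compound 3 (0.79 log units; beyond the scatter) as a modest step, which leaves compound 3 with the strongest inhibition of the three. An oxygen at this position therefore does not by itself weaken inhibition, as the step from chloro to methoxy alone might have suggested, since the outcome depends on what the oxygen carries. Going by these compounds, whether a longer chain on the carbonyl of the acetyl, or an amine in place of the acetoxy, would follow compound 3 remains open. No supporting measurement bears on why the acetyl has so large an effect here.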